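1H-Imidazol-1-yl in Place of 1H-1,2,4-Triazol-1-yl: Compound 4

This account rests on a few compounds, and the source may have more. Where it says the series, first, only, none or still open, it means among the compounds named here.

Inhibition in a functional assay on NCI-H1975 cells (Homo sapiens) for inhibition, read by sulforhodamine B assay, tested at 10 uM (on this read-out lower numbers stand for less inhibition and higher numbers for more inhibition at the one concentration tested (going by the name of the read-out)), for the three measured compounds:
compound 1 `COC(=O)CC(=O)N1N=C(c2ccc(-n3cncn3)cc2)CC1c1ccc(N(C)C)cc1` gives 1.5%
compound 2 `CN(C)c1ccc(C2CC(c3ccc(-n4cncn4)cc3)=NN2C(=O)c2ccc(F)cc2)cc1` gives -1.1%
compound 3 `CN(C)c1ccc(C2CC(c3ccc(-n4cncn4)cc3)=NN2C(=O)/C=C/c2ccccc2)cc1` gives -2.3%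

Compound 1 holds the largest of the three numbers, but the gaps are small: a number 2.6 percentage points lower from compound 1 to compound 2 (within the scatter) and a number 3.8 percentage points lower from compound 1 to compound 3 (within the scatter) both fall within the scatter, as does a number 1.2 percentage points lower from compound 2 to compound 3 (within the scatter), so the three compounds cannot be told apart in this assay, and all of them sit close to no inhibition at the one concentration tested.

Compound 4 `COC(=O)CC(=O)N1N=C(c2ccc(-n3ccnc3)cc2)CC1c1ccc(N(C)C)cc1` differs from compound 1 in a single place: 1H-imidazol-1-yl in place of 1H-1,2,4-triazol-1-yl on an aromatic carbon. Among the measured compounds shown here, none of the measured steps touches this position; each of them exchanges the group on the carbonyl carbon while the five-membered aromatic ring stays the same. The measured steps therefore say nothing direct about this change, and what they do show is that three quite different groups on the carbonyl carbon all leave the read-out near zero. On that basis no step beyond the scatter is expected for compound 4, which means an expected no change at the digits printed from compound 1 to compound 4 (within the scatter). The estimate for compound 4 in this assay is 1.5%, with a range from -8% to 12%.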

Compound 4, a percentage reported as inhibition, at one concentration (the size of the read-out at that concentration, not a potency): -0.1%
Beside the measured number, compound 4's estimate is 1.6 percentage points above it, and the stated range covers the measured number.
By their numbers in this assay, from the lowest: compounds 3, 2, 4 and 1 (each within the scatter of the next).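

Among the compounds shown here, this is the first reading at the aromatic carbon para to a large group, since compounds 1, 2 and 3 all carry 1H-1,2,4-triazol-1-yl there. In this assay, placing 1H-imidazol-1-yl at that position gives a number 1.6 percentage points lower from compound 1 to compound 4 (within the scatter), so with (methoxycarbonyl)methyl held on the carbonyl carbon, a five-membered aromatic ring with 2 hetero atoms and 2 hydrogen-bond acceptors cannot be told apart from one with 3 hetero atoms and 3 hydrogen-bond acceptors. Nothing available offers an account of this result at the level of measured properties.

Because all four compounds sit close to no inhibition at the one concentration tested, the compounds shown cannot tell whether this position would matter on a background that inhibits these cells, nor whether the same exchange reads alike with 4-fluorophenyl or 2-phenylethenyl on the carbonyl carbon. Also open, on these data alone, is what a group of another kind on that aromatic carbon, such as a morpholine, a carboxylic acid or a primary amine, would give in this assay.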